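Exchanging the pyrimidine arm for the tetrahydroisoquinoline arm

This account rests on a few compounds, and the source may have more. Where it says the series, first, only, none or still open, it means among the compounds named here.

Measured compounds in an ADME assay on microsomes from liver (Mus musculus) for metabolic stability, read by LC-MS, with a stated time of 10 min, tested at 0.5 uM; a lower number here means that less of the compound is left, a higher number that more of the compound is left:
Compound 1, `c1ccc2c(c1)CN[C@@H](CN(CC1CCNCC1)[C@H]1CCCc3cccnc31)C2`, gives 13%.
Compound 2, `c1cnc(CN(CCCN2CCNCC2)[C@H]2CCCc3cccnc32)nc1`, gives 78%.
Compound 3, `c1ccc2c(c1)CN[C@@H](CN(CCN1CCNCC1)[C@H]1CCCc3cccnc31)C2`, gives 79%.

Compound 2 stands near the top of these three numbers: its value lies within the scatter of compound 3, and far above compound 1. For the measured compounds named here, the only step between two measured compounds that differ in one place is a number 66 percentage points higher from compound 1 to compound 3 (beyond the scatter), and it concerns the chain carrying the cyclic amine, not the arm changed here. Compound 4, `c1ccc2c(c1)CN[C@@H](CN(CCCN1CCNCC1)[C@H]1CCCc3cccnc31)C2`, differs from compound 2 as follows: 1,2,3,4-tetrahydroisoquinolin-3-yl in place of pyrimidin-2-yl on a saturated chain carbon bound to an amine nitrogen. Going by the values given here, no measured pair shows this exchange directly. What the data do show is that compound 3 already carries the entering group together with a piperazine chain and gives a value within the scatter of compound 2. For compound 4 the step of a number 1 percentage points lower from compound 2 to compound 4 (within the scatter) is therefore expected to stay within the scatter. Compound 4 is estimated at 77%, in a range from 60% to 92%.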

Compound 4, percent of the compound remaining: 92%
For compound 4 the middle estimate is 15 percentage points below the measured one; the measured number falls inside the stated range.
By their numbers in this assay, from the lowest: compound 1; then compounds 2 and 3 (each within the scatter of the next); then compound 4.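

In this assay, 1,2,3,4-tetrahydroisoquinolin-3-yl in place of pyrimidin-2-yl gives a number 14 percentage points higher from compound 2 to compound 4 (beyond the scatter) and so shows that the group on this saturated chain carbon bound to an amine nitrogen can change the amount of compound left, even with the piperazine chain held constant. With the tetrahydroisoquinoline arm kept, (piperazin-1-yl)methyl in place of piperazin-1-yl gives a number 13 percentage points higher from compound 3 to compound 4 (beyond the scatter) and 2-(piperazin-1-yl)ethyl in place of piperidin-4-yl gives a number 79 percentage points higher from compound 1 to compound 4 (beyond the scatter) with that arm unchanged. No measurement at hand accounts for these steps.

From the compounds shown here alone, it remains open whether a chain longer than 2-(piperazin-1-yl)ethyl would leave as much compound. Also open, going by these compounds, is how a morpholine ring in place of the piperazine would behave on this chain.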